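Dienones on prostate cells: estimate for compound 4

This account rests on a few compounds, and the source may have more. Where it says the series, first, only, none or still open, it means among the compounds named here.

Compound 1 `O=C(/C=C/c1ccc(Cl)c([N+](=O)[O-])c1)/C=C/c1ccccc1Oc1ncnc2ccc(Cl)cc12` is one of three dienones measured in a functional assay on PC-3 cells (Homo sapiens) for inhibition, read by MTT assay, with a stated time of 72 h, tested at 10 uM; a lower number here means less inhibition of growth, a higher number more inhibition of growth at the concentration tested. In this assay compound 1 gives 62.5%. Compound 3 `O=C(/C=C/c1ccc(Oc2ncnc3ccc(Cl)cc23)cc1)/C=C/c1cccc(Cl)c1Cl` gives 67.4% and compound 2 `O=C(/C=C/c1ccc(Oc2ncnc3ccc(Cl)cc23)cc1)/C=C/c1ccc(Cl)c([N+](=O)[O-])c1` gives 56.3%, so compound 1 holds the second of the three numbers; its gaps to compound 3 and to compound 2 both lie within the scatter, and no order among the three can be claimed from them.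

Compound 4 `O=C(/C=C/c1ccccc1Oc1ncnc2ccc(Cl)cc12)/C=C/c1c(Cl)cccc1Cl` arises from compound 1 by 2,6-dichlorophenyl in place of 4-chloro-3-nitrophenyl on a double-bonded chain carbon bound to a double-bonded chain carbon. Going by the values given here, the one measured step that bears on this exchange is a number 11.1 percentage points higher from compound 2 to compound 3 (beyond the scatter), where a nitro-bearing chloro ring was likewise replaced by a dichlorophenyl on the chain. The two dichlorophenyl groups are not the same, since the chlorines occupy different positions as named, so the transfer is approximate and the gain may come out smaller.

A step in the same direction is expected, of modest size, a number 5.5 percentage points higher from compound 1 to compound 4 (within the scatter), because a number 11.1 percentage points higher from compound 2 to compound 3 (beyond the scatter) lay beyond the scatter for the analogous change. Compound 4 is accordingly estimated to give 68% in this assay, with a range from 55% to 80%.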

Compound 4, percent growth inhibition at one concentration: 70.1%
The estimate for compound 4 lay 2.1 percentage points below the measured number; low and high end bracket the measured number.
By their numbers in this assay, from the lowest: compounds 2, 1, 3 and 4 (each within the scatter of the next, the first and the last beyond it).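

Working notes on the place on a double-bonded chain carbon bound to a double-bonded chain carbon: in this assay, on the core of compound 1, 2,6-dichlorophenyl in place of 4-chloro-3-nitrophenyl gives a number 7.6 percentage points higher from compound 1 to compound 4 (within the scatter), so this exchange on this core cannot be separated from repeat variation. The nitro group is thus not required at this place for a number of this size on this core, as compound 4 carries none and gives 70.1%. The step of a number 11.1 percentage points higher from compound 2 to compound 3 (beyond the scatter) belongs to a different core and a different dichlorophenyl, so the two steps point the same way, only that one lies beyond the scatter, and no measurement on hand explains either of them.

The compounds shown leave open whether a single chlorine on the phenyl ring would serve as well as the two in 2,6-dichlorophenyl, and whether a ring carrying an amine or a carboxylic acid at this place would hold a number of this size. Also open, going by these compounds, is how 2,6-dichlorophenyl behaves on the core of compound 2, where the comparison with 4-chloro-3-nitrophenyl would test whether the result depends on the core.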